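Thiophene amine series: nitro to chloro swap

The source may hold more compounds than are shown below. What is called first, only, known or untested is meant among the compounds shown, and "the series" means these compounds.

Measured so far in an assay on CHO-K1 cells for displacement of a labelled ligand from adenosine receptor A1 (Homo sapiens), tested at 10 uM; a higher number here means more inhibition at the concentration tested (going by the name of the read-out), a lower number less inhibition:
compound 1 `Nc1sc(-c2ccc(Cl)cc2)c(-c2cccc(C(F)(F)F)c2)c1C(=O)c1ccccc1` gives 59.1%
compound 2 `CCOC(=O)c1c(N)sc(-c2ccc([N+](=O)[O-])cc2)c1-c1cccc(C(F)(F)F)c1` gives 71.4%

Compound 2 holds the higher of the two numbers in this assay; compound 1 sits lower by a margin that is beyond the usual scatter. The two compounds differ in more than one place, so their gap is not broken down into single steps.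

Compound 3 `CCOC(=O)c1c(N)sc(-c2ccc(Cl)cc2)c1-c1cccc(C(F)(F)F)c1` is not yet measured. It differs from compound 2 in one place: chloro in place of nitro on an aromatic carbon. Among the measured compounds shown here, the only other compound carrying chloro in that position is compound 1, but it differs from compound 3 elsewhere as well, so no directly comparable step exists.

For compound 3, a step in this assay of a number 9.4 percentage points lower from compound 2 to compound 3 (within the scatter) is expected, downward, of a size that may not clear the scatter. Compound 3 is estimated at 62%, within a range from 42% to 80%.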

Compound 3, a percentage reported as inhibition, at one concentration (the size of the read-out at that concentration, not a potency): 58.4%
Beside the measured number, compound 3's estimate is 3.6 percentage points above it; the measured number falls inside the stated range.
By their numbers in this assay, from the lowest: compounds 3 and 1 (each within the scatter of the next); then compound 2.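

The nitro position is now read in a single step: in this assay, the change from 4-nitrophenyl to 4-chlorophenyl gives a number 13 percentage points lower from compound 2 to compound 3 (beyond the scatter) and so separates these two groups at this place. With chloro held constant, the carbonyl carbon can also be read, and ethoxy in place of phenyl gives a number 0.7 percentage points lower from compound 1 to compound 3 (within the scatter), so this pair does not separate those two groups. The data on hand offer no explanation for either step.

From the compounds shown here alone, only chloro and nitro are compared at the aromatic carbon, so it remains open how an amine, a nitrile or a methoxy group there would read. Going by these compounds, at the carbonyl carbon, a hydroxyl group, giving the carboxylic acid, or an amine, giving an amide, remains open, as does the pairing of phenyl on the carbonyl with the 4-nitrophenyl group.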